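A few compounds are considered here, and "the series" means these few. Any claim that something is new, unique, unknown or untested is made for them only; others in the source may bear on it.

Measured compounds in this study:
compound 1 `Cc1csc(-c2cccc(CNc3ccc4[nH]nc(C(=O)O)c4c3)c2O)n1` — 23 nM
compound 2 `CN(C)c1noc(-c2cccc(CNc3cnc4nn[nH]c4c3)c2O)n1` — 2900 nM
compound 3 `CNCc1cccc(-c2nc(N(C)C)no2)c1O` — > 30000 nM

In an assay on isolated protein for inhibition of 2-Hydroxyacid oxidase 1 (Homo sapiens), with stated times of 30 min and 15 min (on this read-out lower numbers stand for stronger inhibition and higher numbers for weaker inhibition), compound 1 gives 23 nM, the lowest of the two numbers shown. Compound 2 gives 2900 nM, a higher number, and the gap to compound 1 lies beyond the scatter. For compound 3 the assay reports only a limit, > 30000 nM, which sits at the limit of > 30000 nM in this assay, at which 1 of the 3 values shown sits. Compound 4 `Cc1cccc(CNc2ccc3[nH]nc(C(=O)O)c3c2)c1O` has not yet been measured; it differs from compound 1 by methyl in place of 4-methyl-1,3-thiazol-2-yl on an aromatic carbon. For the measured compounds named here, no measured pair covers this change directly. Starting from compound 1 at 23 nM, the expected step from compound 1 to compound 4 is a 26-fold higher number from compound 1 to compound 4 (1.42 log units; beyond the scatter), a rise beyond the scatter. Compound 4 is therefore expected at 600 nM, with a range from 100 nM to 5000 nM.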

Compound 4, half-maximal inhibitory concentration: 17000 nM
Beside the measured number, compound 4's estimate is 28-fold (1.45 log units) below it; measured number outside the range, above it.
By their numbers in this assay, from the lowest: compound 1; then compound 2; then compound 4. At a limit, above all of these: compound 3.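

In this assay, methyl in place of 4-methyl-1,3-thiazol-2-yl on this aromatic carbon, ortho to a hydroxy group, gives a 740-fold higher number from compound 1 to compound 4 (2.87 log units; beyond the scatter), a large step. This is the first single change shown at this position, and it marks the position as one on which the low number of compound 1 depends. The core of compound 1, kept intact, does not give a low number by itself.

From the compounds shown here alone, whether a phenyl ring or an amide at this position would keep the number low remains open. What lies behind the size of this step is also open, and nothing shown bears on it.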